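This account rests on a few compounds, and the source may have more. Where it says the series, first, only, none or still open, it means among the compounds named here.

In an ADME assay on the whole organism (Rattus norvegicus, strain Harlan-Han Wistar) for metabolic stability (on this read-out lower numbers stand for a shorter-lived compound and higher numbers for a longer-lived compound), three compounds that differ only in the group on the sulfonyl sulfur have been measured. Compound 1 `Cc1ccc2[nH]c(C(=O)N[C@H]3CN(S(=O)(=O)c4ccccc4)C[C@@H]3C(=O)NCCN(C)C)cc2c1` gives 0.2 h, compound 2 `Cc1ccc2[nH]c(C(=O)N[C@H]3CN(S(=O)(=O)c4ccnnc4)C[C@@H]3C(=O)NCCN(C)C)cc2c1` gives 2.7 h, and compound 3 `Cc1ccc2[nH]c(C(=O)N[C@H]3CN(S(=O)(=O)c4ccnc(C)c4)C[C@@H]3C(=O)NCCN(C)C)cc2c1` gives 0.8 h. Compound 3 therefore stands second highest of the three, with compound 2 above it and compound 1 below it.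

The next structure, compound 4 `Cc1ccc2[nH]c(C(=O)N[C@H]3CN(S(=O)(=O)c4cn(C)nc4C)C[C@@H]3C(=O)NCCN(C)C)cc2c1`, has 1,3-dimethyl-1H-pyrazol-4-yl in place of 2-methylpyridin-4-yl on a sulfonyl sulfur. Within the data shown here, three measured steps concern this same place. The large step of a 14-fold higher number from compound 1 to compound 2 (1.13 log units; beyond the scatter) and the modest step of a 4.0-fold higher number from compound 1 to compound 3 (0.60 log units; beyond the scatter) both replace phenyl, while the modest step of a 3.4-fold lower number from compound 2 to compound 3 (0.53 log units; beyond the scatter) exchanges the two replacements. None of them involves the incoming group, so they show only that this place matters in this assay, and they give no direction for the new change. A step within the scatter is therefore expected. The estimated step is a 1.3-fold higher number from compound 3 to compound 4 (0.10 log units; within the scatter). For compound 4 the expected half-life is 1 h, with an estimated range from 0.4 h to 2.5 h.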

Compound 4, half-life: 2.1 h
Compound 4: the middle estimate sits 2.1-fold (0.32 log units) below what was measured; measured number inside the range.
By their numbers in this assay, from the lowest: compound 1; then compound 3; then compounds 4 and 2 (each within the scatter of the next).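

In this assay, the position on the sulfonyl sulfur also tolerates a five-membered aromatic ring: 1,3-dimethyl-1H-pyrazol-4-yl gives a 2.6-fold higher number from compound 3 to compound 4 (0.42 log units; beyond the scatter) and an 11-fold higher number from compound 1 to compound 4 (1.02 log units; beyond the scatter), so it joins pyridazin-4-yl as a replacement for phenyl with a large step. The exchange of those two groups gives a 1.3-fold lower number from compound 2 to compound 4 (0.11 log units; within the scatter), so the half-life does not separate a five-membered from a six-membered ring in this pair, while the unchanged heavy-atom count in the step from 2-methylpyridin-4-yl shows that the size of the group alone does not fix the result. Nothing available explains why the half-life shifts with these groups.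

On these data alone, it remains open whether each methyl group of the 1,3-dimethyl-1H-pyrazol-4-yl group contributes to this result. Also open, as far as these compounds go, is how a saturated ring such as piperidin-4-yl, or a carboxylic acid on the aromatic ring, would fare at this place.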